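Bromo for methylsulfanyl: cytotoxicity outlook for compound 3

The source may report more compounds than this note shows. Statements on the series, on what has been measured and on what is new or still open speak of the compounds shown alone.

Two members of the series have numbers in an ADME assay on THP-1 cells (Homo sapiens) for cytotoxicity, read by resazurin assay, with a stated time of 72 h; on this read-out lower numbers stand for higher toxicity in this test and higher numbers for lower toxicity in this test. Compound 1 `CSc1ccc(C(=O)/C=C/c2ccc([N+](=O)[O-])o2)cc1` gives 13100 nM in this assay, the lowest of the two numbers; its nearest neighbour, compound 2 `Cc1cccc(C(=O)/C=C/c2ccc([N+](=O)[O-])o2)c1`, gives 42100 nM in this assay, a gap beyond the usual scatter. For the measured compounds named here, no pair of measured compounds differs in only one place, so no step size is known from the series itself.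

Compound 3 `O=C(/C=C/c1ccc([N+](=O)[O-])o1)c1ccc(Br)cc1` differs from compound 1 by bromo in place of methylsulfanyl on an aromatic carbon, para to a large group. Going by the values given here, with no measured step of this kind available, the expectation for this change in this assay is a step of no clear direction and not beyond the scatter. Compound 3 is therefore expected to give about 15000 nM in this assay, within a range from 6000 nM to 40000 nM. The implied step a 1.1-fold higher number from compound 1 to compound 3 (0.06 log units; within the scatter) is expected to be small.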

Compound 3, half-maximal cytotoxic concentration: 13400 nM
The estimate for compound 3 lay 1.1-fold (0.05 log units) above the measured number, within the range that was stated.
By their numbers in this assay, from the lowest: compounds 1 and 3 (each within the scatter of the next); then compound 2.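

In this assay, bromo in place of methylsulfanyl on an aromatic carbon, para to a large group, gives a 1.0-fold higher number from compound 1 to compound 3 (0.01 log units; within the scatter), the first one-place step available in the series. At this position, replacing the methylsulfanyl group with a single bromine atom therefore leaves the number within the scatter, so for this pair the sulfur atom is not required to keep the reading at the level of compound 1. No measurement at hand bears on why these two groups read alike.

On these data alone, whether an amine, a carboxylic acid or a longer chain at this position would keep the number at this level remains open. For the compounds shown here, no one-place step links compound 2 to compound 1 or compound 3, so its higher number cannot yet be tied to any single change.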